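This account rests on a few compounds, and the source may have more. Where it says the series, first, only, none or still open, it means among the compounds named here.

In a functional assay on HCT-116 cells (Homo sapiens) for inhibition, read by MTT assay (on this read-out lower numbers stand for stronger inhibition and higher numbers for weaker inhibition), compound 1 `CCN(CC)C1CCN(C(=O)c2cccc(Nc3nc4nc5c(cnn35)CCCCC(=O)Nc3cccc(c3)N4)c2)C1` gives 130 nM and compound 2 `CN1CCC(N(C)C(=O)c2cccc(Nc3nc4nc5c(cnn35)CCCCC(=O)Nc3cccc(c3)N4)c2)CC1` gives 180 nM, so these two stand level within the scatter. Compound 3 `CN1CC(NC(=O)c2cccc(Nc3nc4nc5c(cnn35)CCCCC(=O)Nc3cccc(c3)N4)c2)C1` differs from compound 2 at one place, on a carbonyl carbon: (1-methylazetidin-3-yl)amino in place of methyl(1-methylpiperidin-4-yl)amino on a carbonyl carbon. For the measured compounds named here, only one measured step bears on this, a 1.4-fold higher number from compound 1 to compound 2 (0.14 log units; within the scatter), which exchanged one amine group for another at that same place and stayed within the scatter. As far as these compounds go, the (1-methylazetidin-3-yl)amino group itself is untested, so no shift beyond the scatter is expected, and the estimated step is a 1.1-fold higher number from compound 2 to compound 3 (0.05 log units; within the scatter). For compound 3 the expected value is 200 nM, with a range from 70 nM to 550 nM.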

Compound 3, half-maximal inhibitory concentration: 270 nM
Compound 3: the middle estimate sits 1.4-fold (0.13 log units) below what was measured; the range from low to high includes it.
By their numbers in this assay, from the lowest: compounds 1, 2 and 3 (each within the scatter of the next, the first and the last beyond it).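

In this assay, a four-membered ring with a hydrogen-bond donor can replace a six-membered ring without one on this carbonyl carbon, and the result stays within the scatter (a 1.5-fold higher number from compound 2 to compound 3 (0.18 log units; within the scatter)). Set against the 3-(diethylamino)pyrrolidin-1-yl group, however, (1-methylazetidin-3-yl)amino gives a modest step beyond the scatter (a 2.1-fold higher number from compound 1 to compound 3 (0.32 log units; beyond the scatter)). No measurement here explains either step. Still open, as far as these compounds go, is how an open-chain group, such as 2-(dimethylamino)ethylamino, or a carboxylic acid would fare on this carbonyl carbon.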